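A Dichlorophenyl Ring in Place of a Single Chloro

A few compounds are considered here, and "the series" means these few. Any claim that something is new, unique, unknown or untested is made for them only; others in the source may bear on it.

Compound 1 `CN(CC1=CC[C@H]2C[C@@H]1C2(C)C)Cc1ccc(Cl)cc1` was tested in an assay on HEK293 cells for displacement of a labelled ligand from C-X-C chemokine receptor type 3 (Homo sapiens) (a lower number here means a stronger inhibitor, a higher number a weaker inhibitor), and in this assay compound 1 gives 2510 nM. Among the two numbers reported it stands lowest, but its nearest neighbour, compound 2 `CN(CC1=CC[C@H]2C[C@@H]1C2(C)C)Cc1ccc(Cl)c(Cl)c1`, lies close with 3160 nM. Within the data shown here, the only measured step, a 1.3-fold higher number from compound 1 to compound 2 (0.10 log units; within the scatter), therefore shows no change beyond the scatter. Compound 3 `COc1ccc(-c2ccc(CN(C)CC3=CC[C@H]4C[C@@H]3C4(C)C)cc2)cc1OC` is reported only as a limit in this assay, > 316 nM, and not as a number; this is the limit of > 316 nM in this assay, at which 1 of the 3 values shown sits.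

Compound 4 `CN(CC1=CC[C@H]2C[C@@H]1C2(C)C)Cc1ccc(-c2cc(Cl)cc(Cl)c2)cc1` differs from compound 1 by 3,5-dichlorophenyl in place of chloro on an aromatic carbon, the new group sitting para to a large group. Among the measured compounds shown here, no measured step covers such a change: the single step concerns a chloro added to the aromatic ring and is within the scatter, while compound 3, the other compound carrying a second aromatic ring on the benzyl group, gives only a limit. For the measured compounds named here, nothing among the measured compounds points to a large gain, and the limit of compound 3 leaves open a loss.

In this assay compound 4 is therefore expected to give about 3000 nM, within 800 nM to 12000 nM. The step of a 1.2-fold higher number from compound 1 to compound 4 (0.08 log units; within the scatter) is expected to remain within the scatter, with a real chance that only a limit is reported.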

Compound 4, inhibition constant: > 316 nM
Compound 4 ended at the assay's limit; the forecaster's own chance of this, stated with the estimate: 45%; the middle value lies beyond the limit too.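

In this assay compound 4 is reported only as a limit, > 316 nM, and not as a number, so the step from compound 1 to compound 4 cannot be read. Compound 3 is reported at the same limit: the limit of > 316 nM in this assay, at which 2 of the 4 values shown sit.

The compounds shown leave open how compound 3 and compound 4, each carrying a second aromatic ring, compare with compound 1 or with each other.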